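This account rests on a few compounds, and the source may have more. Where it says the series, first, only, none or still open, it means among the compounds named here.

Compound 1 `C=CCOc1ccc2c(=O)c(-c3cc(OC)c(OC)cc3OC)coc2c1` stands second highest of the three numbers in a functional assay on HepG2 cells (Homo sapiens) for antiproliferative activity, read by MTT assay, with a stated time of 24 h (on this read-out lower numbers stand for stronger inhibition and higher numbers for weaker inhibition), where compound 1 gives 3450 nM; compound 2 `C#CCOc1ccc2c(=O)c(-c3cc(OC)c(OC)cc3OC)coc2c1` gives 4950 nM and compound 3 `COc1cc(OC)c(-c2coc3cc(OCc4cccc(Br)c4)ccc3c2=O)cc1OC` gives 870 nM. The step of a 1.4-fold higher number from compound 1 to compound 2 (0.16 log units; within the scatter) lies within the scatter, whereas a 5.7-fold lower number from compound 2 to compound 3 (0.76 log units; beyond the scatter) is a modest, real lowering. Compound 4 `COc1cc(OC)c(-c2coc3cc(OCc4cccc(C(F)(F)F)c4)ccc3c2=O)cc1OC` differs from compound 1 by 3-(trifluoromethyl)phenyl in place of vinyl on a saturated chain carbon bound to an oxygen on an aromatic ring. The measured change most like this is the one in which 3-bromophenyl took the place of vinyl at the same site, which gave a 4.0-fold lower number from compound 1 to compound 3 (0.60 log units; beyond the scatter). A step of similar direction and size in this assay is therefore expected here, a 3.5-fold lower number from compound 1 to compound 4 (0.54 log units; beyond the scatter). Compound 4 is accordingly estimated at 1000 nM, with a range from 400 nM to 2500 nM.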

Compound 4, half-maximal inhibitory concentration: 610 nM
Compound 4: the middle estimate sits 1.6-fold (0.21 log units) above what was measured, and the stated range covers the measured number.
By their numbers in this assay, from the lowest: compounds 4 and 3 (each within the scatter of the next); then compounds 1 and 2 (each within the scatter of the next).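

At this site, on a saturated chain carbon bound to an oxygen on an aromatic ring, 3-(trifluoromethyl)phenyl also lies clearly below vinyl (a 5.7-fold lower number from compound 1 to compound 4 (0.75 log units; beyond the scatter)) and ethynyl (an 8.1-fold lower number from compound 2 to compound 4 (0.91 log units; beyond the scatter)), so the lowering seen with 3-bromophenyl is no longer confined to one aryl group. Trifluoromethyl in place of bromo on an aromatic carbon does not separate the two aryl compounds (a 1.4-fold lower number from compound 3 to compound 4 (0.15 log units; within the scatter)). Nothing available bears on the reason for these steps. The compounds shown leave open whether unsubstituted benzyl, or a benzyl carrying an amine or a carboxylic acid, keeps these lower numbers.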